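From 3-chlorophenyl to 4-chlorophenyl at the assay limit

The source may hold more compounds than are shown below. What is called first, only, known or untested is meant among the compounds shown, and "the series" means these compounds.

Measured in a functional assay on NCI-H460 cells (Homo sapiens) for cytotoxicity, read by sulforhodamine B assay; on this read-out higher numbers stand for weaker inhibition of growth and lower numbers for stronger inhibition of growth:
- Compound 1 `CC1=CC[C@@H]([C@@](C)(O)CCCC(C)(C)NC(=S)N/N=C\c2ccccc2Cl)CC1`: > 100000 nM
- Compound 2 `CC1=CC[C@@H]([C@@](C)(O)CCCC(C)(C)NC(=S)N/N=C\c2cccc(Cl)c2)CC1`: > 100000 nM

In this assay, compound 2 gives > 100000 nM, which is a limit and not a number. Compound 1 gives > 100000 nM, also a limit. Compound 2 therefore has no numeric value to stand on, and the picture so far is the limit of > 100000 nM in this assay, at which 2 of the 2 values shown sit.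

Compound 3 `CC1=CC[C@@H]([C@@](C)(O)CCCC(C)(C)NC(=S)N/N=C\c2ccc(Cl)cc2)CC1` is still to be measured. It carries 4-chlorophenyl in place of 3-chlorophenyl on a carbon with a double bond to nitrogen.

For the measured compounds named here, only one measured step bears on this change, a step that the two limits leave unreadable from compound 1 to compound 2. It also concerns where the chlorine sits on the phenyl ring, but it has no readable size. No step beyond the scatter is therefore expected in this assay, and no direction can be predicted. The expected step is a number no higher from compound 2 to compound 3 (the limit leaves the size open). Compound 3 is expected at 100000 nM, with an estimated range from 50000 nM to 200000 nM, and another limit is the likeliest report.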

Compound 3, concentration for total growth inhibition: > 100000 nM
Compound 3: a limit, no number (the forecaster's own chance of this, stated with the estimate: 80%); the middle value sits exactly at the limit.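

In this assay compound 3 gives > 100000 nM, a limit and not a number. For the compounds shown here, no step among compound 1, compound 2 and compound 3 can be read, and all three share one result: the limit of > 100000 nM in this assay, at which 3 of the 3 values shown sit. The compounds shown leave open whether moving the chlorine around the phenyl ring changes growth inhibition at all.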